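The source may report more compounds than this note shows. Statements on the series, on what has been measured and on what is new or still open speak of the compounds shown alone.

Measured compounds:
Compound 1 (`COc1ccc(/C=C(/C(=O)c2cc(OC)c(OC)c(OC)c2)c2ccc(OC)cc2OC)cc1`) gives 90000 nM
Compound 2 (`COc1ccc(/C=C(/C(=O)c2cc(OC)c(OC)c(OC)c2)c2ccccc2O)cc1O`) gives 49000 nM
Compound 3 (`COc1ccc(/C=C(/C(=O)c2cc(OC)c(OC)c(OC)c2)c2ccccc2O)cc1`) gives 370000 nM

All three were tested in a functional assay on K562 cells (Homo sapiens) for antiproliferative activity, read by MTT assay, with a stated time of 5 days (a higher number here means a weaker inhibitor, a lower number a stronger inhibitor), and compound 3 has the highest number, making it the weakest of the three. Compound 4 (`COc1ccc(/C=C(/C(=O)c2cc(OC)c(OC)c(OC)c2)c2ccccc2O)cc1F`) differs from compound 3 by one change (fluoro in place of hydrogen on an aromatic carbon) with fluoro in place of hydrogen on an aromatic carbon. The closest measured step removes a hydroxy from that same carbon (a 7.6-fold higher number from compound 2 to compound 3 (0.88 log units; beyond the scatter)). The other step (a 4.1-fold higher number from compound 1 to compound 3 (0.61 log units; beyond the scatter)) concerns a different ring and bears on this change only loosely. Fluoro is not hydroxy, so only part of the first step is expected to be recovered, as a modest move to a lower number. The estimated step is a 2.5-fold lower number from compound 3 to compound 4 (0.39 log units; beyond the scatter) and would lie in that direction. The expected value for compound 4 is 150000 nM (estimated range 50000 nM to 400000 nM).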

Compound 4, half-maximal inhibitory concentration: 60000 nM
The estimate for compound 4 lay 2.5-fold (0.40 log units) above the measured number, within the range that was stated.
By their numbers in this assay, from the lowest: compounds 2, 4 and 1 (each within the scatter of the next); then compound 3.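

In this assay fluoro on the aromatic carbon ortho to a methoxy group gives a 6.2-fold lower number from compound 3 to compound 4 (0.79 log units; beyond the scatter) and so shows that this position does not need a hydroxy for the number to fall. Fluoro in place of hydroxy gives a 1.2-fold higher number from compound 2 to compound 4 (0.09 log units; within the scatter) and so the two groups cannot be told apart here. Nothing available explains why either group has this effect. From the compounds shown here alone, whether an amine or a chlorine atom on the same carbon would act like fluoro and hydroxy remains open.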